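The source may report more compounds than this note shows. Statements on the series, on what has been measured and on what is new or still open speak of the compounds shown alone.

Measured so far in a functional assay (aorta) with Rattus norvegicus as the target; on this read-out lower numbers stand for an effect already at smaller amounts and higher numbers for an effect only at larger amounts of compound:
compound 1 `CC(C)C(C)NC1=NS(=O)(=O)c2cc(Br)ccc2N1`: 2.6 uM
compound 2 `O=S1(=O)NC(NC2CCC2)=Nc2ccc(Br)cc21`: 21.7 uM
compound 3 `CC(C)C(C)NC1=NS(=O)(=O)c2cc(I)ccc2N1`: 0.94 uM

Compound 1 and compound 3 share one core and differ in a single place: iodo in place of bromo on an aromatic carbon. In this assay that change gave a 2.8-fold lower number from compound 1 to compound 3 (0.44 log units; beyond the scatter). Compound 2 stands on another core; the difference between the two cores is not broken down here, and compound 2 shows the highest of the three numbers. Compound 4 `O=S1(=O)NC(NC2CCC2)=Nc2ccc(I)cc21` has not yet been measured; it differs from compound 2 in the same place and in the same way: iodo in place of bromo on an aromatic carbon. Within the data shown here, because the one measured example of this change gave a 2.8-fold lower number from compound 1 to compound 3 (0.44 log units; beyond the scatter), a step of about a 2.7-fold lower number from compound 2 to compound 4 (0.43 log units; beyond the scatter) is expected here as well. Compound 4 is therefore estimated to give 8 uM in this assay, expected to fall between 4 uM and 16 uM.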

Compound 4, concentration for half-maximal effect: 22.2 uM
The estimate for compound 4 lay 2.8-fold (0.44 log units) below the measured number; the measured number lies above the stated range.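

On the core of compound 2, iodo in place of bromo on an aromatic carbon gave a 1.0-fold higher number from compound 2 to compound 4 (0.01 log units; within the scatter) in this assay, so this pair shows no effect of the change that stands clear of the scatter. Set beside the earlier step, the change did not carry over at the same size from one core to the other: the same change on two cores in this assay, a 2.8-fold lower number (0.44 log units; beyond the scatter) from compound 1 to compound 3 and a 1.0-fold higher number (0.01 log units; within the scatter) from compound 2 to compound 4, 2.8-fold (0.45 log units) apart, beyond the scatter of two such steps

These two pairs show that the step depends on the core in this small set, but they do not show what in the cores makes the difference, and they give no rule for any further core. As far as these compounds go, only bromo and iodo appear at this place, so it remains open how chloro, methoxy or a nitrile there would read on either core.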